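Removing one methoxy group from the pyrazole-side aryl ring

The compounds below may be only part of what the source reports. "The series", "measured", "known", "first", "only" and "open" are said of these compounds alone.

Measured compounds and their values:
compound 1 `COc1ccc(-c2cc(/C=C/C(=O)c3ccc(N)cc3)[nH]n2)cc1` gives 10200 nM
compound 2 `COc1cc(-c2cc(/C=C/C(=O)c3ccc(N)cc3)[nH]n2)cc(OC)c1OC` gives 7020 nM
compound 3 `COc1ccc(C(=O)/C=C/c2cc(-c3cc(OC)c(OC)c(OC)c3)n[nH]2)cc1OC` gives 4590 nM

All three were tested in a functional assay on A549 cells (Homo sapiens) for inhibition, read by sulforhodamine B assay, with a stated time of 48 h; a lower number here means a stronger inhibitor of growth, a higher number a weaker inhibitor of growth. Compound 2 stands second highest of the three numbers; its nearest neighbour is compound 1, and its furthest is compound 3, and both gaps lie within the scatter. Among the measured compounds shown here, the only single-point step recorded is a 1.5-fold lower number from compound 2 to compound 3 (0.18 log units; within the scatter), a change on the carbonyl side of the molecule, and it too lies within the scatter.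

Compound 4 `COc1ccc(-c2cc(/C=C/C(=O)c3ccc(N)cc3)[nH]n2)cc1OC` differs from compound 2 by hydrogen in place of methoxy on an aromatic carbon. For the measured compounds named here, no measured step touches this aryl ring directly. Compound 1, which carries a single methoxy on that ring, gives 10200 nM, and compound 2, with three, gives 7020 nM; the difference between these two lies within the scatter, so there is no sign that the methoxy count on this ring moves the number much.

Compound 4 is therefore expected to land between these two, with an estimated step of a 1.2-fold higher number from compound 2 to compound 4 (0.08 log units; within the scatter), within the scatter. The estimate for compound 4 is 8500 nM, with a range from 4000 nM to 18000 nM.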

Compound 4, concentration for total growth inhibition: 10100 nM
Beside the measured number, compound 4's estimate is 1.2-fold (0.07 log units) below it, and the stated range covers the measured number.
By their numbers in this assay, from the lowest: compounds 3, 2, 4 and 1 (each within the scatter of the next, the first and the last beyond it).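

In this assay, the methoxy group at this position can now be judged by itself, one change at a time. Taking it away gives a 1.4-fold higher number from compound 2 to compound 4 (0.16 log units; within the scatter) and adding it to the ring of compound 1 gives a 1.0-fold lower number from compound 1 to compound 4 (0.00 log units; within the scatter) as the second step, and both steps lie within the scatter. On this ring, then, neither single methoxy change separates the compounds in this assay. Compound 1 and compound 2 differ in two places. Taken alone, that pair could not give this reading. Nothing available here explains this result.

The compounds shown leave open whether a different group at this position, such as a hydroxyl, a chlorine or an ethoxy, would behave like hydrogen and methoxy. They also leave open whether the same holds with the 3,4-dimethoxyphenyl group on the carbonyl carbon.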